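This account rests on a few compounds, and the source may have more. Where it says the series, first, only, none or still open, it means among the compounds named here.

Measured compounds:
compound 1, `COC(=O)C1=C(C)NC(C)=C(C(=O)OC)C1c1ccccc1`, 28.2 nM
compound 2, `COC(=O)C1=C(C)N=C(C)/C(=C(\O)OC)C1c1ccc(F)cc1`, 129 nM
compound 3, `COC(=O)C1=C(C)N=C(C)/C(=C(\O)OC)C1c1cccc(OC(C)=O)c1`, 6030 nM

In a functional assay (muscle tissue) with Cavia porcellus as the target (a higher number here means that more compound is needed for the effect, a lower number that less compound is needed), compound 2 gives 129 nM, the second highest of the three numbers. Its nearest neighbour is compound 1, which in this assay gives 28.2 nM, a lower number and a gap beyond the scatter. Far above both stands compound 3, which gives 6030 nM.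

Compound 4, `COC(=O)C1=C(C)N=C(C)/C(=C(\O)OC)C1c1ccccc1C`, has not yet been measured in this assay. It differs from compound 2 in one place: 2-methylphenyl in place of 4-fluorophenyl on a saturated ring carbon.

For the measured compounds named here, no step between measured compounds is given for a change of this kind, so the expectation rests on the three values alone. Compound 1, which carries a plain phenyl on the same carbon, gives 28.2 nM, and compound 3 with its 3-acetoxyphenyl gives 6030 nM, so the aromatic substituent moves the number over a wide span. Compound 4 is expected to land at a lower number than compound 2, with a step of moderate size, a 2.6-fold lower number from compound 2 to compound 4 (0.41 log units; beyond the scatter). The estimate for compound 4 is 50 nM, within a range from 10 nM to 300 nM.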

Compound 4, half-maximal effective concentration: 6.03 nM
Estimate against measurement, compound 4: 8.3-fold (0.92 log units) above; the whole stated range lies above it.
By their numbers in this assay, from the lowest: compound 4; then compound 1; then compound 2; then compound 3.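

In this assay, putting 2-methylphenyl in place of 4-fluorophenyl on the saturated ring carbon gives a 21-fold lower number from compound 2 to compound 4 (1.33 log units; beyond the scatter). For the compounds shown here, this is the first step read at this position, and it shows that the number responds strongly here even when the heavy-atom count, the single aromatic ring of carbon and the absence of hydrogen-bond donors and acceptors all stay the same. Nothing measured on these compounds explains the size of the step.

The compounds shown leave open whether the step belongs to the arrival of the methyl group, to the departure of the fluorine, or to both, since the two changes occur together here. As far as these compounds go, how this assay would respond to an ethyl group or a chlorine atom in place of that methyl also remains unknown.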